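Moving the methoxy group around the amide ring

The source may hold more compounds than are shown below. What is called first, only, known or untested is meant among the compounds shown, and "the series" means these compounds.

Compound 1 `CC(=O)Nc1ccc(Cc2noc(CCC(=O)O)n2)cc1` carries a hydroxy on a carbonyl carbon. In a functional assay on the whole organism (strain C57BL/6) for inhibition, with Mus musculus as the target, read by paw edema, with stated times of 1 h and 4 h, at a dose of 100 mg/kg by the oral route (on this read-out higher numbers stand for more inhibition at the one dose given (going by the name of the read-out) and lower numbers for less inhibition), compound 1 gives 75.3%, the second highest of the three numbers measured. Compound 2 `COc1cccc(NC(=O)CCc2nc(Cc3ccc(NC(C)=O)cc3)no2)c1` gives 35.6%, and compound 3 `COc1ccccc1NC(=O)CCc1nc(Cc2ccc(NC(C)=O)cc2)no1` gives 87.7%. Compound 4 `COc1ccc(NC(=O)CCc2nc(Cc3ccc(NC(C)=O)cc3)no2)cc1` differs from compound 1 by (4-methoxyphenyl)amino in place of hydroxy on a carbonyl carbon. Among the compounds with values here, two measured steps bear on this change: a number 39.7 percentage points lower from compound 1 to compound 2 (beyond the scatter) and a number 12.4 percentage points higher from compound 1 to compound 3 (beyond the scatter); the two amides also differ from each other by a number 52.1 percentage points higher from compound 2 to compound 3 (beyond the scatter). Replacing the hydroxy with a methoxyphenylamino group thus moved the number strongly in both directions, so the direction for the remaining methoxy position cannot be settled from these data. Compound 4 is expected to show a number 13.3 percentage points lower from compound 1 to compound 4 (beyond the scatter), with wide uncertainty. For compound 4 the estimate is 62%, expected to fall between 30% and 90%.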

Compound 4, a percentage reported as inhibition, in the whole organism at one dose (the size of the read-out at that dose, not a potency): 49.3%
Compound 4: the middle estimate sits 12.7 percentage points above what was measured; measured number inside the range.
By their numbers in this assay, from the lowest: compound 2; then compound 4; then compound 1; then compound 3.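

The 4-methoxyphenyl amide also falls short of the hydroxy compound (a number 26 percentage points lower from compound 1 to compound 4 (beyond the scatter)), so among the three methoxyphenylamino amides shown, only compound 3 exceeds compound 1. Changing the 2-methoxyphenyl to 4-methoxyphenyl costs far more (a number 38.4 percentage points lower from compound 3 to compound 4 (beyond the scatter)) than changing the 3-methoxyphenyl to 4-methoxyphenyl gains (a number 13.7 percentage points higher from compound 2 to compound 4 (beyond the scatter)), which leaves compound 3 clearly apart from both other amides. No measurement here accounts for this dependence on methoxy placement. Still open, going by these compounds, is how a plain phenylamino group or a benzylamino group would compare in place of hydroxy.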